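From 4-fluorophenyl to 4-(trifluoromethyl)phenyl in the series

The compounds below may be only part of what the source reports. "The series", "measured", "known", "first", "only" and "open" are said of these compounds alone.

Measured in an ADME assay on MT2 cells (Homo sapiens) for cytotoxicity, read by XTT assay, with a stated time of 4 days; on this read-out higher numbers stand for lower toxicity in this test and lower numbers for higher toxicity in this test:
compound 1 `Cc1ccc(NC(=O)C(=O)NC(c2nc(C)c(CO)s2)C2CCCCN2)cc1F`: > 88000 nM
compound 2 `CC(=O)c1ccc(NC(=O)C(=O)NC(c2nc(C)c(CO)s2)C2CCCCN2)cc1`: > 107000 nM
compound 3 `Cc1nc(C(NC(=O)C(=O)Nc2ccc(F)cc2)C2CCCCN2)sc1CO`: > 113000 nM

All three entries are limits and not numbers. Compound 3 therefore stands only at a limit, > 113000 nM, and no number places it relative to the other two compounds.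

Compound 4 `Cc1nc(C(NC(=O)C(=O)Nc2ccc(C(F)(F)F)cc2)C2CCCCN2)sc1CO` differs from compound 3 in one group: trifluoromethyl in place of fluoro on an aromatic carbon. The change is trifluoromethyl in place of fluoro on an aromatic carbon.

Three measured steps alter the aromatic group on the amide-type nitrogen: a step that the two limits leave unreadable from compound 1 to compound 2, a step that the two limits leave unreadable from compound 1 to compound 3 and a step that the two limits leave unreadable from compound 2 to compound 3. None of them has a readable size. On this evidence, no step beyond the scatter is expected in this assay, in either direction, and a further limit is the likeliest report.

The estimated step is an at least 1.1-fold lower number from compound 3 to compound 4 (0.05 log units; that floor lies within the scatter). For compound 4 the expected value is 100000 nM, with an estimated range of 45000 nM to 130000 nM.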

Compound 4, half-maximal cytotoxic concentration: > 75500 nM
Compound 4 gave a limit, no number; the forecaster's own chance of this, stated with the estimate: 80%; the middle value does not contradict the limit.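

In this assay compound 4 gives only a limit, as do compound 1, compound 2 and compound 3, and no step among these four compounds can be read. The compounds shown leave open whether changing the aromatic group on the amide-type nitrogen alters this read-out at all.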